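A few compounds are considered here, and "the series" means these few. Any claim that something is new, unique, unknown or untested is made for them only; others in the source may bear on it.

Measured so far in an in vitro functional assay on HEK285-7 cells for antagonist activity at prostaglandin D2 receptor 2 (Homo sapiens), read by BRET and beta-arrestin recruitment; on this read-out higher numbers stand for larger maximal responses and lower numbers for smaller maximal responses:
Compound 1, `CS(=O)(=O)Nc1cccc(-c2nc(C(c3ccc(F)cc3)c3ccc(F)cc3)sc2CC(=O)O)c1`, gives 80%.
Compound 2, `O=C(O)Cc1sc(C(c2ccc(F)cc2)c2ccc(F)cc2)nc1-c1cc(F)nc(F)c1`, gives 80%.
Compound 3, `Cc1cc(-c2nc(C(c3ccc(F)cc3)c3ccc(F)cc3)sc2CC(=O)O)ccn1`, gives 80%.

The three compounds share one core and differ only in the aromatic group that sits on one carbon of it. Compound 3 stands level with compounds 1 and 2 at the digits read. The three steps that connect them, no change at the digits printed from compound 1 to compound 2 (within the scatter), no change at the digits printed from compound 1 to compound 3 (within the scatter) and no change at the digits printed from compound 2 to compound 3 (within the scatter), all stay within the scatter, although the groups exchanged are quite different from one another: 3-(methanesulfonamido)phenyl, 2,6-difluoropyridin-4-yl and 2-methylpyridin-4-yl.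

Compound 4, `O=C(O)Cc1sc(C(c2ccc(F)cc2)c2ccc(F)cc2)nc1-c1ccncc1`, has not been measured yet. It differs from compound 3 in one place: hydrogen in place of methyl on an aromatic carbon. Read one bond further out, the change is 2-methylpyridin-4-yl to pyridin-4-yl. This is a smaller alteration than any of the three measured swaps, each of which left the maximal response unchanged within the scatter. On that basis the expected step of no change at the digits printed from compound 3 to compound 4 (within the scatter) is none beyond the scatter. Compound 4 is therefore estimated to give 80% in this assay, with a likely range from 65% to 92%.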

Compound 4, largest response reached (reported as efficacy), in percent of the reference or control that the assay uses: 80%
For compound 4 middle estimate and measured number coincide at the digits printed; measured number inside the range.
By their numbers in this assay, from the lowest: compounds 1, 2, 3 and 4 (each within the scatter of the next).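

In this assay, taking away the methyl group next to the ring nitrogen and leaving hydrogen gives no change at the digits printed from compound 3 to compound 4 (within the scatter) and shows that this methyl group is not required for the maximal response to stay at this level. The earlier compounds shown here all carried something on the aromatic group at this carbon of the shared core, whereas pyridin-4-yl carries nothing on its ring, and it still matches the two other groups, with no change at the digits printed from compound 2 to compound 4 (within the scatter) and no change at the digits printed from compound 1 to compound 4 (within the scatter). Nothing available explains why such different groups give maximal responses within the scatter of one another.

Since all four compounds sit within the scatter of one another, they do not show which change at this place, if any, would move the maximal response beyond the scatter. An amino group, a methoxy group or a chlorine atom in place of the hydrogen next to the ring nitrogen remains an open case, as does a plain phenyl ring in place of pyridin-4-yl.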